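This account rests on a few compounds, and the source may have more. Where it says the series, first, only, none or still open, it means among the compounds named here.

In a functional assay on KB-VIN10 cells (Homo sapiens) for inhibition, with a stated time of 72 h (a lower number here means a stronger inhibitor, a higher number a weaker inhibitor), compound 1 `COc1ccc(S(=O)(=O)N2CCc3cccc(-c4ccco4)c32)cc1` gives 79.2 nM, which lies within the scatter of both other measured compounds: compound 2 `COc1ccc(S(=O)(=O)N2CCc3cccc(-c4ccc(F)c(F)c4)c32)cc1` at 46 nM and compound 3 `COc1ccc(S(=O)(=O)N2CCc3cccc(-c4ccc(F)cc4)c32)cc1` at 94.6 nM. In compound 4 `COc1ccc(-c2cccc3c2N(S(=O)(=O)c2ccc(OC)cc2)CC3)cc1`, 4-methoxyphenyl takes the place of furan-2-yl on an aromatic carbon (4-methoxyphenyl in place of furan-2-yl on an aromatic carbon). Two measured swaps of the same group bear on this change: 3,4-difluorophenyl gives a 1.7-fold lower number from compound 1 to compound 2 (0.24 log units; within the scatter), and 4-fluorophenyl gives a 1.2-fold higher number from compound 1 to compound 3 (0.08 log units; within the scatter). Removing one fluoro gives a modest step, a 2.1-fold higher number from compound 2 to compound 3 (0.31 log units; beyond the scatter). With both phenyl swaps inside the scatter, no step beyond the scatter is expected in this assay. The estimated step is a 1.1-fold lower number from compound 1 to compound 4 (0.05 log units; within the scatter). For compound 4 the estimated value is 70 nM, with an expected range of 25 nM to 200 nM.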

Compound 4, half-maximal inhibitory concentration: 352 nM
Compound 4: the middle estimate sits 5.0-fold (0.70 log units) below what was measured; the whole stated range lies below it.
By their numbers in this assay, from the lowest: compounds 2, 1 and 3 (each within the scatter of the next, the first and the last beyond it); then compound 4.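

In this assay, this position proves sensitive to what the phenyl group carries. Fluorinated phenyl groups in place of furan-2-yl stayed within the scatter, yet 4-methoxyphenyl gives a 4.4-fold higher number from compound 1 to compound 4 (0.65 log units; beyond the scatter). Methoxy in place of fluoro alone gives a 3.7-fold higher number from compound 3 to compound 4 (0.57 log units; beyond the scatter), and 4-methoxyphenyl in place of 3,4-difluorophenyl gives a 7.7-fold higher number from compound 2 to compound 4 (0.88 log units; beyond the scatter), so a single group on the phenyl ring can outweigh the swap of furan-2-yl for phenyl.

No measurement here accounts for these steps. As far as these compounds go, whether an amine or a hydroxy group in place of that methoxy would bring the number back towards that of compound 3 remains open.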